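Second chloro on the aryl sulfone of compound 2

The source may report more compounds than this note shows. Statements on the series, on what has been measured and on what is new or still open speak of the compounds shown alone.

Three members of the series have numbers in a functional assay on HeLa cells for agonist activity at 5-hydroxytryptamine receptor 6 (Homo sapiens), read by cAMP accumulation and immunoassay; a higher number here means that more compound is needed for the effect, a lower number that less compound is needed. Compound 1 `CN1CCC(n2cc(S(=O)(=O)c3ccccc3)c3cccnc32)C1` gives 2040 nM, compound 3 `CN1CCCC(n2cc(S(=O)(=O)c3cccc(F)c3)c3cccnc32)C1` gives 306 nM, and compound 2 `O=S(=O)(c1cccc(Cl)c1)c1cn(C2CCCNC2)c2ncccc12` gives 30 nM. Compound 2 thus stands lowest of the three, its distance to compound 3 and to compound 1 each beyond the usual scatter, so it is the most potent of those measured. No pair among these three differs in only one place, so no single change can be read off directly.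

Compound 4 `O=S(=O)(c1cc(Cl)cc(Cl)c1)c1cn(C2CCCNC2)c2ncccc12` follows from compound 2 by chloro in place of hydrogen on an aromatic carbon, the 3-chlorophenyl becoming a 3,5-dichlorophenyl. Nothing measured tells how a second chloro on this ring acts in this assay. A modest step is expected, probably toward a somewhat higher number, but not clearly beyond the scatter, and the step from compound 2 to compound 4 is estimated as a 1.7-fold higher number from compound 2 to compound 4 (0.22 log units; within the scatter). Compound 4 is therefore expected at about 50 nM, within a range of 12 nM to 200 nM.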

Compound 4, half-maximal effective concentration: 297 nM
Beside the measured number, compound 4's estimate is 5.9-fold (0.77 log units) below it; measured number above the stated range.
By their numbers in this assay, from the lowest: compound 2; then compounds 4 and 3 (each within the scatter of the next); then compound 1.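

Chloro in place of hydrogen on this aromatic carbon gives a 9.9-fold higher number from compound 2 to compound 4 (1.00 log units; beyond the scatter) in this assay. Within the data shown here, this is the first single-place change readable, and it shows that the added chlorine, a single heavy atom meta to the existing chloro group, is enough to move the number beyond the scatter. So the 3-chlorophenyl of compound 2 cannot be extended to the 3,5-dichlorophenyl of compound 4 without loss of potency in this assay, and no measurement here bears on why the number rises.

Going by these compounds, it remains open whether this step is specific to chloro or would also follow from another group on the same carbon, such as a methoxy or a nitrile. Also open, on these data alone, is whether such a group would give a step of similar size on the unsubstituted phenyl sulfone.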